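From Bromo to Cyano: Estimating Compound 4

This account rests on a few compounds, and the source may have more. Where it says the series, first, only, none or still open, it means among the compounds named here.

Values in a functional assay on HeLa cells (Homo sapiens) for cytotoxicity, read by MTT assay, with a stated time of 24 h (a higher number here means a weaker inhibitor, a lower number a stronger inhibitor), are as follows
compound 1 `COc1cc(/C=C2\CN(C)C/C(=C\c3ccc(Br)cc3)C2=O)cc(OC)c1` gives 5900 nM
compound 2 `COc1cc(/C=C2\CN(C)C/C(=C\c3ccc(C#N)cc3)C2=O)cc(OC)c1` gives 3420 nM
compound 3 `COc1cc(/C=C2\CN(C)C/C(=C\c3ccc(Br)cc3)C2=O)cc(OC)c1OC` gives 11900 nM

Compound 3 (11900 nM) carries the highest number of the three, yet its gap to compound 1 lies within the scatter of repeated measurements. Only the gap to compound 2 (3420 nM) lies beyond that scatter.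

Compound 4 `COc1cc(/C=C2\CN(C)C/C(=C\c3ccc(C#N)cc3)C2=O)cc(OC)c1OC` differs from compound 3 by cyano in place of bromo on an aromatic carbon, para to a large group (cyano in place of bromo on an aromatic carbon). Among the measured compounds shown here, the only other measured step is methoxy in place of hydrogen on an aromatic carbon (a 2.0-fold higher number from compound 1 to compound 3 (0.30 log units; within the scatter)), so the swap has not yet been seen on the core that carries this extra methoxy. The same swap has been measured just once, and that single step (a 1.7-fold lower number from compound 1 to compound 2 (0.24 log units; within the scatter)) is the basis for expecting a small move toward a lower number in this assay, one that stays within the scatter. The expected change is a 1.7-fold lower number from compound 3 to compound 4 (0.24 log units; within the scatter) and remains an estimate resting on one pair. Compound 4 is expected at 6900 nM with an estimated range from 3800 nM to 12500 nM in repeat measurements.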

Compound 4, half-maximal inhibitory concentration: 3420 nM
Compound 4: the middle estimate sits 2.0-fold (0.30 log units) above what was measured, and the stated range ends above it.
By their numbers in this assay, from the lowest: compounds 2, 4, 1 and 3 (each within the scatter of the next, the first and the last beyond it).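

In this assay, the change from bromo to cyano now has a second reading, on the core that carries the extra methoxy, and here the step is larger than the scatter: a 3.5-fold lower number from compound 3 to compound 4 (0.54 log units; beyond the scatter). Both readings of this 4-bromophenyl to 4-cyanophenyl change point toward a lower number, and their sizes cannot be told apart: the same change on two cores in this assay, a 1.7-fold lower number (0.24 log units; within the scatter) from compound 1 to compound 2 and a 3.5-fold lower number (0.54 log units; beyond the scatter) from compound 3 to compound 4, 2.0-fold (0.30 log units) apart, within the scatter of two such steps. The extra methoxy, read for the first time on the cyano core, gives no change at the digits printed from compound 2 to compound 4 (within the scatter), and its two readings also cannot be told apart: the same change on two cores in this assay, a 2.0-fold higher number (0.30 log units; within the scatter) from compound 1 to compound 3 and no change at the digits printed (within the scatter) from compound 2 to compound 4, 2.0-fold (0.30 log units) apart, within the scatter of two such steps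

From the compounds shown here alone, how an amine, a carboxylic acid or a longer chain at this place would compare with bromo and cyano stays open. Also open, going by these compounds, is which difference between the two groups, such as the triple bond or the hydrogen-bond acceptor of cyano, goes with the lower number.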